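Changing the aryl group on the sulfonyl sulfur

This account rests on a few compounds, and the source may have more. Where it says the series, first, only, none or still open, it means among the compounds named here.

Measured compounds:
compound 1 `COc1cc2nc(N3CCN(C(=O)OCc4ccccc4)CC3)nc(N)c2cc1OC` — 63000 nM
compound 2 `COc1cc2nc(N3CCN(C(=O)c4ccc(C(F)(F)F)cc4)CC3)nc(N)c2cc1OC` — > 100000 nM, a limit of the assay
compound 3 `COc1cc2nc(N3CCN(S(=O)(=O)c4ccc(C)cc4)CC3)nc(N)c2cc1OC` — 30000 nM

Three compounds share one core and differ only in the group on the ring nitrogen. In a functional assay on PC-3 cells (Homo sapiens) for inhibition (on this read-out lower numbers stand for stronger inhibition and higher numbers for weaker inhibition), compound 3 gives the lowest of the two numbers shown. Its nearest neighbour is compound 1, and the step of a 2.1-fold lower number from compound 1 to compound 3 (0.32 log units; beyond the scatter) is modest but beyond the scatter. Compound 2 reports only a limit, (the limit of > 100000 nM in this assay, at which 1 of the 3 values shown sits), so the step of an at least 1.5-fold higher number from compound 1 to compound 2 (0.20 log units; that floor lies within the scatter) is known merely as a floor.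

Compound 4 `COc1cc2nc(N3CCN(S(=O)(=O)c4cc(Cl)ccc4Cl)CC3)nc(N)c2cc1OC` is not yet measured. It differs from compound 3 in one place: 2,5-dichlorophenyl in place of 4-methylphenyl on a sulfonyl sulfur. Among the compounds with values here, none of the measured steps touches the aryl group on the sulfonyl sulfur; the step from compound 1 to compound 3 changes the linker itself, and the step from compound 1 to compound 2 changes the group on a carbonyl carbon. So the data give no measured step of the same kind to lean on. With nothing to point either way, compound 4 is expected to sit close to compound 3, with no change at the digits printed from compound 3 to compound 4 (within the scatter) not beyond the scatter. The estimate for compound 4 in this assay is 30000 nM, within 10000 nM to 90000 nM.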

Compound 4, half-maximal inhibitory concentration: 60000 nM
Compound 4: middle estimate off by 2.0-fold (0.30 log units), on the low side; low and high end bracket the measured number.
By their numbers in this assay, from the lowest: compounds 3, 4 and 1 (each within the scatter of the next, the first and the last beyond it). At a limit, above all of these: compound 2.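

In this assay the change to 2,5-dichlorophenyl in place of 4-methylphenyl on a sulfonyl sulfur gives a 2.0-fold higher number from compound 3 to compound 4 (0.30 log units; within the scatter) and so leaves the two compounds indistinguishable on this read-out. The earlier steps shown here changed the linker or the group on a carbonyl carbon and said nothing about this position; here, two chlorine atoms on the aryl ring in place of one methyl group produce no difference that this assay can resolve, so the sulfonyl aryl position accepts both groups with the numbers remaining within the scatter of each other. No measurement given here bears on why the two compounds read alike.

Still open is how far this holds for other groups on the sulfonyl sulfur, since both aryl groups shown are six-membered aromatic rings of carbon only, and an amine or a carboxylic acid on that ring, a pyridine ring, or a plain alkyl chain on the sulfur could read differently. On these data alone, it is also open whether any group at this position can take the number well under that of compound 3 (30000 nM) in this series.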